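Unsaturating one chain of compound 3

The compounds below may be only part of what the source reports. "The series", "measured", "known", "first", "only" and "open" are said of these compounds alone.

In a functional assay on MCF7 cells (Homo sapiens) for antiproliferative activity, read by MTT assay, with a stated time of 48 h (a lower number here means a stronger inhibitor, a higher number a weaker inhibitor), compound 1 (`COc1cc(CNC(=O)CCCCCCC(C)C)ccc1OCCCCOc1ccc(C(N)=S)cc1`) gives a half-maximal inhibitory concentration of 4990 nM and compound 2 (`COc1cc(CNC(=O)CCCCCCC(C)C)ccc1OC(=O)CCC(=O)Oc1ccc(-c2cc(=S)ss2)cc1`) gives 2560 nM and these two values lie within the usual scatter of each other. In this assay compound 3 (`COc1cc(CNC(=O)CCCCCCC(C)C)ccc1OC(=O)c1ccc(C(N)=S)cc1`) gives no number but only the limit > 50000 nM and this value is a limit of the assay. Compound 3 alone stands there (the limit of > 50000 nM in this assay, at which 1 of the 3 values shown sits).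

Compound 4 (`COc1cc(CNC(=O)CCCC/C=C/C(C)C)ccc1OC(=O)c1ccc(C(N)=S)cc1`) shares the core of compound 3 and differs in one group: 3-methylbut-1-en-1-yl stands in place of isopentyl on a saturated chain carbon, four bonds along the chain from a carbonyl carbon (3-methylbut-1-en-1-yl in place of isopentyl on a saturated chain carbon, four bonds along the chain from a carbonyl carbon). For the measured compounds named here, no measured pair shows what this change does in this assay and the only guide is the parent. The expectation therefore rests on compound 3 with its limit > 50000 nM and no shift beyond the scatter is expected from one added double bond outside aromatic rings. The expected move is a step that the limit leaves unreadable from compound 3 to compound 4 and it is estimated to stay within the scatter. For compound 4 the estimated half-maximal inhibitory concentration is 60000 nM with an expected range from 20000 nM to 150000 nM and the assay may well report only a limit again.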

Compound 4, half-maximal inhibitory concentration: 39400 nM
Compound 4: the middle estimate sits 1.5-fold (0.18 log units) above what was measured, within the range that was stated.
By their numbers in this assay, from the lowest: compounds 2 and 1 (each within the scatter of the next); then compound 4. At a limit, above all of these: compound 3.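

In this assay, for the compounds shown here, 3-methylbut-1-en-1-yl in place of isopentyl on a saturated chain carbon, four bonds along the chain from a carbonyl carbon, gives the first number for this ester-linked series, with compound 4 at 39400 nM. The change can be read only as a floor, an at least 1.2-fold lower number from compound 3 to compound 4 (0.10 log units; that floor lies within the scatter), so the compounds show that the double bond at this place leaves a value the assay can report, but they do not show a gain beyond the scatter. Compound 3 has only a limit of the assay, and the true size of the step stays unread because of that limit: the limit of > 50000 nM in this assay, at which 1 of the 4 values shown sits.

What the compounds shown leave open is how this assay would read a longer chain, an amine or a carboxylic acid at this place, and whether the cis form of the double bond would read like compound 4. Also open, as far as these compounds go, is whether the same change would do anything on the chains of compound 1 and compound 2, which carry isopentyl at this place on a different linker.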